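The source may hold more compounds than are shown below. What is called first, only, known or untested is meant among the compounds shown, and "the series" means these compounds.

Compound 1 `CC(=O)c1ccc2c(c1)C(n1ccccc1=O)=CC(C)(C)O2` stands highest of the two measured compounds: in a functional assay (trachea) with Rattus norvegicus as the target (on this read-out lower numbers stand for lower potency and higher numbers for higher potency (the scale is a negative logarithm)), compound 1 gives 6.65. Compound 2 `CC1(C)C=C(n2ccccc2=O)c2cc(OC(=O)Nc3ccccc3)ccc2O1` gives 4.89 in this assay, a gap beyond the scatter. Compound 3 `CC1(C)C=C(n2ccccc2=O)c2cc(-c3ccncc3)ccc2O1` differs from compound 1 by one change: pyridin-4-yl in place of acetyl on an aromatic carbon. For the measured compounds named here, no measured pair shows this change, so its effect is unknown, and a moderate loss is expected, since compound 1 stands highest of the measured compounds at 6.65. Compound 3 is expected to give 6.1 in this assay, between 5.2 and 7. The expected step of a number 0.55 log units lower from compound 1 to compound 3 (beyond the scatter) lies at the edge of the scatter.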

Compound 3, logarithm of the reciprocal of the active concentration, log(1/C): 6.32
Compound 3: middle estimate off by 0.22 log units, on the low side; low and high end bracket the measured number.
By their numbers in this assay, from the lowest: compound 2; then compound 3; then compound 1.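

In this assay, pyridin-4-yl in place of acetyl gives a number 0.33 log units lower from compound 1 to compound 3 (beyond the scatter), a modest step. This shows that this aromatic carbon can carry a whole six-membered aromatic ring, much larger than acetyl, with only a modest loss of potency. Nothing available here explains why the loss stays modest.

On these data alone, it remains open whether the ring nitrogen of pyridin-4-yl matters, which a plain phenyl ring at this carbon would test. How an amine or a carboxylic acid would fare here is also unknown.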